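The compounds below may be only part of what the source reports. "The series", "measured", "known", "first", "only" and "open" are said of these compounds alone.

Measured in an assay on HEK293 cells for positive allosteric modulation of metabotropic glutamate receptor 5 (Homo sapiens), read by FLIPR, with a stated time of 1 h; a higher number here means that more compound is needed for the effect, a lower number that less compound is needed:
Compound 1 `CC(C)CN1CCc2nc(C#Cc3ccccc3)sc2C1` gives > 10000 nM, which is a limit of the assay.
Compound 2 `O=C(C1CCCCC1)N1CCc2nc(C#Cc3ccccc3)sc2C1` gives 167 nM.
Compound 3 `CC1CCC(C(=O)N2CCc3nc(C#Cc4ccccc4)sc3C2)CC1` gives 190 nM.

Compound 3 and compound 2 give numbers within the scatter of each other; the remaining value is a limit, (the limit of > 10000 nM in this assay, at which 1 of the 3 values shown sits). Compound 4 `O=C(C1CCCCO1)N1CCc2nc(C#Cc3ccccc3)sc2C1` differs from compound 3 by oxan-2-yl in place of 4-methylcyclohexyl on a carbonyl carbon. Among the compounds with values here, two measured steps bear on this. The first gave an at least 59-fold lower number from compound 1 to compound 2 (1.77 log units; beyond the scatter), a large move tied to the amide itself. The second gave a 1.1-fold higher number from compound 2 to compound 3 (0.06 log units; within the scatter), a change confined to the ring on the carbonyl carbon. Within the data shown here, since compound 4 keeps the amide and alters only that ring, as in a 1.1-fold higher number from compound 2 to compound 3 (0.06 log units; within the scatter), a step of similar size is expected, a 1.6-fold higher number from compound 3 to compound 4 (0.20 log units; within the scatter). Compound 4 is estimated at 300 nM, with a range from 90 nM to 1000 nM.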

Compound 4, half-maximal effective concentration: 320 nM
Compound 4: the middle estimate sits 1.1-fold (0.03 log units) below what was measured; the range from low to high includes it.
By their numbers in this assay, from the lowest: compounds 2, 3 and 4 (each within the scatter of the next). At a limit, above all of these: compound 1.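

In this assay the carbocyclic ring on the carbonyl carbon can give way to a ring with an oxygen: oxan-2-yl in place of 4-methylcyclohexyl gives a 1.7-fold higher number from compound 3 to compound 4 (0.23 log units; within the scatter) and oxan-2-yl in place of cyclohexyl gives a 1.9-fold higher number from compound 2 to compound 4 (0.28 log units; within the scatter) with neither step leaving the scatter. With oxan-2-yl the amide still shows an at least 31-fold lower number from compound 1 to compound 4 (1.49 log units; beyond the scatter) against the isobutyl amine. Compound 1 stands at a limit: the limit of > 10000 nM in this assay, at which 1 of the 4 values shown sits.

Open, from the compounds shown here alone, is whether an amine or a carboxylic acid on the ring at the carbonyl carbon keeps numbers like these. Also open, going by these compounds, is whether a longer chain can replace the ring.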